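Cyano in Place of Chloro at the Aromatic Carbon

A few compounds are considered here, and "the series" means these few. Any claim that something is new, unique, unknown or untested is made for them only; others in the source may bear on it.

Compound 1, `O=C(CCC1=CCN(Cc2ccc(F)cc2)C1=O)NO`: 5310 nM
Compound 2, `O=C(CCC1=CCN(Cc2cccc(Cl)c2)C1=O)NO`: 4620 nM
Compound 3, `O=C(CCC1=CCN(Cc2ccc(Cl)cc2)C1=O)NO`: 4620 nM

Of the compounds shown here, three sharing one core have been measured in a functional assay on PC-3 cells (Homo sapiens) for inhibition, read by sulforhodamine B assay; on this read-out higher numbers stand for weaker inhibition of growth and lower numbers for stronger inhibition of growth. Compound 3 stands level with compound 2 at the digits shown, and these two give the lowest numbers of the three; still, the only counted step, a 1.1-fold lower number from compound 1 to compound 3 (0.06 log units; within the scatter), is within the scatter, so none of the three can be called more or less active than another.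

Compound 4, `N#Cc1ccc(CN2CC=C(CCC(=O)NO)C2=O)cc1`, differs from compound 3 in one place: cyano in place of chloro on an aromatic carbon. Among the measured compounds shown here, the one measured step that bears on this change is the one from compound 1 to compound 3, where one halogen replaced another at the same aromatic carbon and gave a 1.1-fold lower number from compound 1 to compound 3 (0.06 log units; within the scatter). For the measured compounds named here, a nitrile replacing a halogen has no measured precedent here. Going by the values given here, with only that small step to go on, the expectation is a change of a 1.0-fold lower number from compound 3 to compound 4 (0.00 log units; within the scatter), none beyond the scatter. Compound 4 is therefore estimated at 4600 nM, in a range from 2300 nM to 9500 nM.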

Compound 4, concentration for 50% growth inhibition: > 10000 nM
Compound 4: a limit, no number; the forecaster's own chance of this, stated with the estimate: 5%; middle value at least 2.1-fold (0.33 log units) from the limit.
By their numbers in this assay, from the lowest: compounds 2, 3 and 1 (each within the scatter of the next). At a limit, above all of these: compound 4.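

Until now, the aromatic carbon para to a large group had shown no change beyond the scatter, with fluoro in compound 1 and chloro in compound 3 too close to separate, but in this assay cyano in place of chloro moves the read-out beyond it: an at least 2.1-fold higher number from compound 3 to compound 4 (0.33 log units; beyond the scatter). Against fluoro the result is less firm: an at least 1.8-fold higher number from compound 1 to compound 4 (0.27 log units; that floor lies within the scatter). Compound 4 carries a limit and not a number, so both steps give only a floor: the limit of > 10000 nM in this assay, at which 1 of the 4 values shown sits.

The compounds shown leave open how far past that limit compound 4 lies, and so how large the change really is. They also leave open whether a methoxy group or an amine on the same aromatic carbon would behave like chloro or like cyano.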